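This account rests on a few compounds, and the source may have more. Where it says the series, first, only, none or still open, it means among the compounds named here.

Going by the values given here, compound 1 `CC1=C(C(=O)OCCO[N+](=O)[O-])C(c2cccc3nonc23)C([N+](=O)[O-])=C(C)C1` holds the lower of the two numbers measured so far: in a functional assay (ileum) for antagonist activity, with Cavia porcellus as the target (a lower number here means a stronger inhibitor, a higher number a weaker inhibitor), compound 1 gives 3890 nM. Compound 2 `CC1=C(C(=O)O[C@H](C)CO[N+](=O)[O-])[C@H](c2cccc3nonc23)C([N+](=O)[O-])=C(C)C1` gives 36500 nM in this assay, a gap that lies beyond the scatter. Compound 3 `CC1=C(C(=O)OCCCCO[N+](=O)[O-])C(c2cccc3nonc23)C([N+](=O)[O-])=C(C)C1` is not yet measured; it differs from compound 1 by 2-(nitrooxy)ethyl in place of nitrooxy on a saturated chain carbon, two bonds along the chain from an oxygen next to a carbonyl group. Among the compounds with values here, no measured pair shows a step of this kind, so the expected step of a 1.0-fold higher number from compound 1 to compound 3 (0.01 log units; within the scatter) is put at none beyond the scatter, with the direction left open. For compound 3 in this assay the estimate is 4000 nM, with a range from 1500 nM to 12000 nM.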

Compound 3, half-maximal inhibitory concentration: 878 nM
Estimate against measurement, compound 3: 4.6-fold (0.66 log units) above, and the stated range ends above it.
By their numbers in this assay, from the lowest: compound 3; then compound 1; then compound 2.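

Going from 2-(nitrooxy)ethyl to 4-(nitrooxy)butyl at this saturated chain position gives a 4.4-fold lower number from compound 1 to compound 3 (0.65 log units; beyond the scatter) in this assay, so the length of the ester chain matters here. This is a single step and does not establish a trend with chain length. Nothing measured on these compounds bears on why the longer chain goes with the lower number.

Still open, going by these compounds, is how a 3-(nitrooxy)propyl chain or a longer chain such as 6-(nitrooxy)hexyl would read. Also open, on these data alone, is whether the nitrooxy group itself is needed, which a hydroxyl in its place on the butyl chain would test.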